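Carboxy in place of methoxy on an anilide for HDAC6

The source may hold more compounds than are shown below. What is called first, only, known or untested is meant among the compounds shown, and "the series" means these compounds.

Measured compounds:
Compound 1 `COc1ccc(NC(=O)c2ccc(CNc3nccc(-c4cccnc4)n3)cc2)c(N)c1`: in an assay on isolated protein for inhibition of protein deacetylase HDAC6 (Homo sapiens), read by fluorescence, with stated times of 3 h and 60 min (on this read-out lower numbers stand for stronger inhibition and higher numbers for weaker inhibition), compound 1 gives > 20000 nM, which is a limit of the assay and not a number.
Compound 2 `CC(=O)N1C(NCc2ccc(C(=O)Nc3ccccc3N)cc2)=NC(=O)C1Cc1ccccc1`: in this assay compound 2 gives > 20000 nM, likewise only a limit.

Going by the values given here, compound 1 therefore stands at the edge of what this assay reports, and the one other value shown stands there as well, so that both sit at the limit of > 20000 nM in this assay, at which 2 of the 2 values shown sit. Among the compounds with values here, no step between two measured compounds is available, since compound 1 and compound 2 differ in more than one place and both are limits.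

The next compound, compound 3 `Nc1cc(C(=O)O)ccc1NC(=O)c1ccc(CNc2nccc(-c3cccnc3)n2)cc1`, differs from compound 1 by carboxy in place of methoxy on an aromatic carbon. Within the data shown here, with compound 1 at the limit, no measured step can tell in which direction, or how far, such a change moves the read-out. The account expects compound 3 to stay at or near the limit, and the expected step from compound 1 to compound 3 is a step that the limit leaves unreadable from compound 1 to compound 3, which lies within the usual scatter. The estimate for compound 3 in this assay is 30000 nM, with a range from 5000 nM to 200000 nM.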

Compound 3, half-maximal inhibitory concentration: > 20000 nM
Compound 3 was reported as a limit; the forecaster's own chance of this, stated with the estimate: 75%; the middle value is on the limit's open side.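

No new step can be read from compound 1 to compound 3, since in this assay compound 3, like compound 1, is reported only as a limit of the assay: the limit of > 20000 nM in this assay, at which 3 of the 3 values shown sit.

The compounds shown leave open whether carboxy in place of methoxy changes the read-out at all, and which change to these structures would give a value inside the limit in this assay.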